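Ring oxygen in place of cyclohexyl on the imine nitrogen

The source may hold more compounds than are shown below. What is called first, only, known or untested is meant among the compounds shown, and "the series" means these compounds.

Compound 1 `CC(C)CC/N=C(\NC#N)Nc1cccnc1`: 20 mg/kg
Compound 2 `CC(C)/N=C(\NC#N)Nc1cccnc1`: 2.5 mg/kg
Compound 3 `N#CN/C(=N\C1CCCCC1)Nc1cccnc1`: 20 mg/kg

In a functional assay on the whole organism (blood, strain Wistar-Okamoto) with Rattus norvegicus as the target, with a stated time of 5 days (on this read-out lower numbers stand for an effect already at smaller amounts and higher numbers for an effect only at larger amounts of compound), compound 3 stands level with compound 1, the two together giving the highest numbers of the three; compound 2 lies furthest from it, and the change is an 8.0-fold higher number from compound 2 to compound 3 (0.90 log units; beyond the scatter). Compound 4 `N#CN/C(=N\CC1CCCO1)Nc1cccnc1` carries the change ((oxolan-2-yl)methyl in place of cyclohexyl on a double-bonded nitrogen). Within the data shown here, two measured steps touch this position: no change at the digits printed from compound 1 to compound 3 (within the scatter) and an 8.0-fold higher number from compound 2 to compound 3 (0.90 log units; beyond the scatter). Among the measured compounds shown here, neither replaces a carbocycle with a ring bearing oxygen, so no measured step directly matches. The only improvement seen came when the group on the double-bonded nitrogen became smaller, which the new group also is. Compound 4 is therefore expected to give 10 mg/kg (range 3 mg/kg to 40 mg/kg), a step of a 2.0-fold lower number from compound 3 to compound 4 (0.30 log units; within the scatter).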

Compound 4, minimum effective dose: 50 mg/kg
Compound 4: the middle estimate sits 5.0-fold (0.70 log units) below what was measured; the measured number lies above the stated range.
By their numbers in this assay, from the lowest: compound 2; then compounds 1 and 3 (each within the scatter of the next); then compound 4.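

In this assay the (oxolan-2-yl)methyl group on the double-bonded nitrogen gives a 2.5-fold higher number from compound 3 to compound 4 (0.40 log units; beyond the scatter) and also a 2.5-fold higher number from compound 1 to compound 4 (0.40 log units; beyond the scatter) so this position, where isopentyl and cyclohexyl had stood level, does respond to a change that brings in a ring oxygen. Against the isopropyl group the change is larger, with a 20-fold higher number from compound 2 to compound 4 (1.30 log units; beyond the scatter) so a smaller group on this nitrogen does not by itself bring a lower number. Nothing available accounts for this shift.

Left open is how a cyclopentylmethyl group would compare, which would separate the ring oxygen from the rest of the change. Also open, as far as these compounds go, is where a tert-butyl or cyclopropyl group would stand against the isopropyl group of compound 2.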